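The source may report more compounds than this note shows. Statements on the series, on what has been measured and on what is new or still open speak of the compounds shown alone.

Measured compounds:
compound 1 `COc1cc(NC(C)CCCNC(=O)Nc2cccc(F)c2)c2ncccc2c1` — 24000 nM
compound 2 `COc1cc(NC(C)CCCNC(=O)Nc2cccc(Cl)c2)c2ncccc2c1` — 37000 nM
compound 3 `COc1cc(NC(C)CCCNC(=O)NNC(=O)Nc2ccc(Br)cc2)c2ncccc2c1` — 27000 nM

In a functional assay on NCI-H460 cells (Homo sapiens) for inhibition, read by MTT assay, with a stated time of 72 h (on this read-out higher numbers stand for weaker inhibition and lower numbers for stronger inhibition), compound 1 has the lowest of the three numbers, but both steps away from it stay within the scatter: a 1.5-fold higher number from compound 1 to compound 2 (0.19 log units; within the scatter) and a 1.1-fold higher number from compound 1 to compound 3 (0.05 log units; within the scatter). Compound 4 `COc1cc(NC(C)CCCNC(=O)Nc2cccc(C(F)(F)F)c2)c2ncccc2c1` differs from compound 1 by trifluoromethyl in place of fluoro on an aromatic carbon. Within the data shown here, the one measured step that bears on this change is the exchange of one halogen for another on an aromatic carbon, a 1.5-fold higher number from compound 1 to compound 2 (0.19 log units; within the scatter), which did not leave the scatter; the step of a 1.4-fold lower number from compound 2 to compound 3 (0.14 log units; within the scatter) alters a different part of the chain and adds nothing here. No step beyond the scatter is therefore expected, a 1.0-fold higher number from compound 1 to compound 4 (0.02 log units; within the scatter). Compound 4 is estimated at 25000 nM, with a range of 10000 nM to 60000 nM.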

Compound 4, half-maximal inhibitory concentration: 21000 nM
Estimate against measurement, compound 4: 1.2-fold (0.08 log units) above; measured number inside the range.
By their numbers in this assay, from the lowest: compounds 4, 1, 3 and 2 (each within the scatter of the next).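

In this assay the aromatic carbon of the 3-fluorophenyl group accepts trifluoromethyl, with 4 heavy atoms in place of 1, without leaving the scatter (a 1.1-fold lower number from compound 1 to compound 4 (0.06 log units; within the scatter)). The same holds against chloro (a 1.8-fold lower number from compound 2 to compound 4 (0.25 log units; within the scatter)) and against the ((4-bromophenyl)carbamoyl)amino end (a 1.3-fold lower number from compound 3 to compound 4 (0.11 log units; within the scatter)), so all four compounds remain within the scatter of the next. No evidence is available that bears on a cause for this result. Going by these compounds, whether an amine or a carboxylic acid on this aromatic carbon would move the number beyond the scatter remains open, as does the effect of a longer chain.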